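A Pyridin-2-yl Swap Judged From One Measured Value

This account rests on a few compounds, and the source may have more. Where it says the series, first, only, none or still open, it means among the compounds named here.

Within the data shown here, compound 1 `COc1ccc(/C=C2\S/C(=N\c3csc(-c4ccc(Cl)cc4)c3)NC2=O)cc1` is the only member of this small set that comes with a number. In a functional assay on SW-620 cells (Homo sapiens) for cytotoxicity, read by MTT assay, with a stated time of 72 h (on this read-out lower numbers stand for stronger inhibition and higher numbers for weaker inhibition), compound 1 gives 28100 nM, a weak effect on its own terms. A second entry, compound 2 `CCCCCC/C=C1\S/C(=N\c2csc(-c3ccc(Cl)cc3)c2)NC1=O`, carries no number: in this assay compound 2 is recorded as "not determined" (no result reported), so it adds nothing to the comparison.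

The compound still to be tested, compound 3 `O=C1N/C(=N/c2csc(-c3ccc(Cl)cc3)c2)S/C1=C\c1ccccn1`, differs from compound 1 in a single place: pyridin-2-yl in place of 4-methoxyphenyl on a double-bonded chain carbon bound to a double-bonded ring carbon, in words pyridin-2-yl in place of 4-methoxyphenyl on a double-bonded chain carbon bound to a double-bonded ring carbon. Among the measured compounds shown here, no step between two measured compounds exists here, so the effect of this change cannot be read from any pair. With compound 1 at 28100 nM as the sole anchor, the expectation is that the change stays within the usual scatter, with no clear direction either way. Compound 3 is therefore estimated at 30000 nM, within a range from 10000 nM to 90000 nM. The step this estimate implies is a 1.1-fold higher number from compound 1 to compound 3 (0.03 log units; within the scatter), expected rather than known.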

Compound 3, half-maximal inhibitory concentration: > 50000 nM
Compound 3 gave a limit, no number; the forecaster's own chance of this, stated with the estimate: 20%; middle value at least 1.6-fold (0.22 log units) away from the limit.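

In this assay compound 3 gives > 50000 nM, which is a limit of the assay and not a number. Pyridin-2-yl in place of 4-methoxyphenyl on a double-bonded chain carbon bound to a double-bonded ring carbon gives an at least 1.7-fold higher number from compound 1 to compound 3 (0.25 log units; that floor lies within the scatter), so this position now has its first readable step, and that step offers no sign of a lower number from this change. Only a floor on the step can be stated, and how far it extends is unknown because the reading of compound 3 ends at a limit: the limit of > 50000 nM in this assay, at which 1 of the 3 values shown sits.

Steps involving compound 2 cannot be read, so the compounds shown do not tell how an open chain in this place compares with either aromatic ring. From the compounds shown here alone, whether a pyridin-3-yl, a 4-aminophenyl or a group carrying a carboxylic acid in the same place would bring the number down remains open, as does whether the ring nitrogen of pyridin-2-yl or the loss of the methoxy group accounts for the step.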